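Replacing the ring nitrogen group with formyl

The source may hold more compounds than are shown below. What is called first, only, known or untested is meant among the compounds shown, and "the series" means these compounds.

Measured in a functional assay on PANC-1 cells (Homo sapiens) for inhibition, read by XTT assay, with a stated time of 72 h; a lower number here means a stronger inhibitor, a higher number a weaker inhibitor:
- Compound 1 `CC(C)(C)OC(=O)N1CCC[C@H]1COCCCCCCCCC/C=C/c1ccc(-c2ccccc2)cc1`: 80000 nM
- Compound 2 `Cc1ccc([S+]([O-])N2CCC[C@H]2COCCCCCCCCC/C=C/c2ccc(-c3ccccc3)cc2)cc1`: > 100000 nM (a limit)

Compound 2 has no number, only a limit of the assay, > 100000 nM. The next compound is compound 3 `O=CN1CCC[C@H]1COCCCCCCCCC/C=C/c1ccc(-c2ccccc2)cc1`, and the change is a group of 2 heavy atoms (1 carbon, 1 oxygen; no ring) in place of a group of 9 heavy atoms (7 carbon, 1 oxygen, 1 sulfur; one six-membered aromatic ring of carbon only), on an amine nitrogen in a ring. A formyl group thus takes the place of the group with one six-membered aromatic ring of carbon only, on an amine nitrogen in a ring.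

Within the data shown here, one measured step bears on this, made at the same nitrogen: an at least 1.2-fold higher number from compound 1 to compound 2 (0.09 log units; that floor lies within the scatter). It stays within the scatter and rests on a limit, so it gives no firm size or direction. Only a small move in this assay is therefore expected, perhaps none beyond the scatter, and any move should be towards a lower number. The expected change is an at least 1.6-fold lower number from compound 2 to compound 3 (0.22 log units; that floor lies within the scatter). For compound 3 the estimated value is 60000 nM, with an expected range of 25000 nM to 100000 nM.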

Compound 3, half-maximal inhibitory concentration: 56700 nM
Estimate against measurement, compound 3: 1.1-fold (0.02 log units) above, and the stated range covers the measured number.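

In this assay, among these compounds, the formyl group gives a second actual number for a group on this amine nitrogen, where the earlier pair offered only one number and one limit. The step of a 1.4-fold lower number from compound 1 to compound 3 (0.15 log units; within the scatter) shows that hydrogen in place of tert-butoxy on the carbonyl carbon leaves the reading within the scatter, so the size of this acyl group makes no measurable difference here. The other step, an at least 1.7-fold lower number from compound 2 to compound 3 (0.24 log units; that floor lies within the scatter), has a floor within the scatter and gives no true size, as one of its ends is a limit rather than a number: the limit of > 100000 nM in this assay, at which 1 of the 3 values shown sits.

From the compounds shown here alone, it remains open whether any group on this nitrogen can move the number beyond the scatter. What an acetyl group, or a free amine with hydrogen on this nitrogen, would give also stays unanswered.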